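Carbonyl substituent exchange on the piperidine-linked core

A few compounds are considered here, and "the series" means these few. Any claim that something is new, unique, unknown or untested is made for them only; others in the source may bear on it.

Within the data shown here, compound 3 `O=C(NC1CC[S+]([O-])CC1)N1CCC(c2nc(-c3ccc4ccccc4n3)no2)CC1` stands second highest of the three numbers so far: in a functional assay on Shh Light II cells (Mus musculus) for inhibition, read by a luciferase reporter (on this read-out higher numbers stand for weaker inhibition and lower numbers for stronger inhibition), compound 3 gives 850 nM. Its nearest neighbour is compound 1 `C[C@@H]1C[C@H](c2nc(-c3ccc4ccccc4n3)no2)CCN1C(=O)Nc1ccccc1Cl`, which gives 2400 nM, a gap beyond the scatter. The furthest is compound 2 `O=C(NC1CCCCC1)N1CCN(c2nc(-c3ccc4ccccc4n3)no2)CC1`, which gives 53 nM, also well beyond the scatter; compound 2 differs from compound 3 in more than one place. Compound 4 `O=C(OCc1ccccc1)N1CCC(c2nc(-c3ccc4ccccc4n3)no2)CC1` is not yet measured. It differs from compound 3 by a group of 8 heavy atoms (7 carbon, 1 oxygen; one six-membered aromatic ring of carbon only) in place of a group of 8 heavy atoms (5 carbon, 1 nitrogen, 1 oxygen, 1 sulfur; one six-membered non-aromatic ring with 1 hetero atom), on a carbonyl carbon. Among the measured compounds shown here, no single-change step between measured compounds is known, so the size of this step cannot be read from a precedent. A moderate step toward stronger inhibition, beyond the scatter, is expected; the expected step is a 2.8-fold lower number from compound 3 to compound 4 (0.45 log units; beyond the scatter). Compound 4 is expected to give 300 nM, within a range from 80 nM to 1200 nM.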

Compound 4, half-maximal inhibitory concentration: > 2500 nM
Compound 4: no number, only a limit (the forecaster's own chance of this, stated with the estimate: 5%); at least 8.3-fold (0.92 log units) between middle value and limit.
By their numbers in this assay, from the lowest: compound 2; then compound 3; then compound 1. At a limit, above all of these: compound 4.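

Among these compounds, this is the first single-change step: on a carbonyl carbon whose other neighbour is an amide-type nitrogen in a ring, benzyloxy replaces the sulfur-bearing ring group, with an at least 2.9-fold higher number from compound 3 to compound 4 (0.46 log units; beyond the scatter) in this assay. Two groups of 8 heavy atoms are therefore not interchangeable at this place. For compound 4, > 2500 nM is a limit of the assay and not a number: the limit of > 2500 nM in this assay, at which 1 of the 4 values shown sits.

Whether the ring oxygen-free aromatic part or the linking oxygen of benzyloxy accounts for the step remains open. A benzylamino group on the same carbonyl carbon would separate the two.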